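The source may report more compounds than this note shows. Statements on the series, on what has been measured and on what is new or still open speak of the compounds shown alone.

In a functional assay on PANC-1 cells (Homo sapiens) for inhibition, read by MTT assay, with a stated time of 24 h, tested at 10 uM (a higher number here means more inhibition at the concentration tested (going by the name of the read-out), a lower number less inhibition), the three measured compounds give these numbers: compound 1 `CC(C)=CCC1Cc2c(O)cc(=O)n(CCCO)c2CC1(C)C` gives 25.6%; compound 2 `CCOc1cc(=O)n(CCCO)c2c1CC(CC=C(C)C)C(C)(C)C2` gives 66.5%; compound 3 `CC(C)=CCC/C(C)=C/COc1cc(=O)n(CCCO)c2c1CC(CC=C(C)C)C(C)(C)C2` gives 10.6%.

Compound 2 stands highest of the three: a number 40.9 percentage points higher from compound 1 to compound 2 (beyond the scatter), and a number 55.9 percentage points lower from compound 2 to compound 3 (beyond the scatter).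

Compound 4 `CC(C)=CCC1Cc2c(OCCCNS(=O)(=O)c3ccc(Cl)cc3)cc(=O)n(CCCO)c2CC1(C)C` differs from compound 2 in one place: (((4-chlorophenyl)sulfonyl)amino)methyl in place of hydrogen on a saturated chain carbon, two bonds along the chain from an oxygen on an aromatic ring. The step that bears most on this is a number 55.9 percentage points lower from compound 2 to compound 3 (beyond the scatter), where a large group entered on the chain carbon bound to the ring oxygen and the number fell by a large amount. The step of a number 40.9 percentage points higher from compound 1 to compound 2 (beyond the scatter) shows that a small ethyl on that oxygen raised the number, but compound 4 extends the chain far beyond that. A sizeable drop is therefore expected: a number 31.5 percentage points lower from compound 2 to compound 4 (beyond the scatter). For compound 4 the estimate is 35%, with a range from 12% to 58%.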

Compound 4, a percentage reported as inhibition, at one concentration (the size of the read-out at that concentration, not a potency): 24.7%
Estimate against measurement, compound 4: 10.3 percentage points above, within the range that was stated.
By their numbers in this assay, from the lowest: compound 3; then compounds 4 and 1 (each within the scatter of the next); then compound 2.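

In this assay, extending the ethyl of compound 2 with (((4-chlorophenyl)sulfonyl)amino)methyl, on a saturated chain carbon two bonds along the chain from an oxygen on an aromatic ring, gives a number 41.8 percentage points lower from compound 2 to compound 4 (beyond the scatter). The fall seen with compound 3 is therefore not confined to its all-carbon chain: a group with a sulfonyl, a nitrogen and a chlorophenyl ring also lowers the number. No measured evidence accounts for this fall. Still open, on these data alone, is whether a short chain ending in an amine would hold the number of compound 2 at this place, and whether the chlorine matters.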